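The compounds below may be only part of what the source reports. "The series", "measured", "known", "first", "only" and "open" are said of these compounds alone.

Measured so far:
- compound 1 `COc1ncc(-c2ccc3ncnc(Nc4ccc(OCCO)cc4)c3c2)cc1NS(C)(=O)=O`: 4860 nM
- compound 2 `COc1ncc(-c2ccc3ncnc(Nc4ccc(OCCO)c(F)c4)c3c2)cc1NS(=O)(=O)c1ccc(F)cc1F`: 9160 nM

Both compounds were tested in a functional assay on HCT-116 cells (Homo sapiens) for antiproliferative activity, read by sulforhodamine B assay, with a stated time of 72 h; on this read-out higher numbers stand for weaker inhibition and lower numbers for stronger inhibition. Compound 1 gives 4860 nM and compound 2 gives 9160 nM; these two numbers lie within the usual scatter of each other, so neither compound can be called the stronger or the weaker of the pair, and compound 1 simply stands as one of two near-equal results.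

Compound 3 `COc1ncc(-c2ccc3ncnc(Nc4ccc(OCCO)cc4)c3c2)cc1NS(=O)(=O)c1ccc(F)cc1F` has not yet been measured. It differs from compound 1 in a single place: 2,4-difluorophenyl in place of methyl on a sulfonyl sulfur. In plain terms, a small one-carbon group on the sulfonyl sulfur gives way to a fluorinated aromatic ring. The same (2,4-difluorophenyl)sulfonyl group is present in compound 2, which also carries an additional change elsewhere, so no clean comparison of this change on its own is available.

Given that compound 2 gives 9160 nM, the expectation is that the step of a 1.5-fold higher number from compound 1 to compound 3 (0.19 log units; within the scatter) is small, if anything toward a somewhat higher number, and within or close to the scatter. Compound 3 is therefore expected to give about 7500 nM, with a likely range from 3000 nM to 18000 nM.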

Compound 3, half-maximal inhibitory concentration: 1060 nM
Compound 3: the middle estimate sits 7.1-fold (0.85 log units) above what was measured; measured number below the stated range.
By their numbers in this assay, from the lowest: compound 3; then compounds 1 and 2 (each within the scatter of the next).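

In this assay, putting 2,4-difluorophenyl in place of methyl on the sulfonyl sulfur gives a 4.6-fold lower number from compound 1 to compound 3 (0.66 log units; beyond the scatter), so this site accepts a much larger aromatic group and the change goes with stronger inhibition, something compounds 1 and 2 could not show because they differ in more than one place. The step from the other side, hydrogen in place of fluoro on an aromatic carbon, gives an 8.6-fold lower number from compound 2 to compound 3 (0.94 log units; beyond the scatter), which shows that the gain seen with the (2,4-difluorophenyl)sulfonyl group depends on the rest of the molecule: a single fluoro elsewhere is enough to shift the number beyond the scatter. Nothing measured alongside these compounds gives a reason for either step.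

The compounds shown leave open whether the aromatic ring itself or its two fluorines carry the first step, a question that a plain phenyl group on the sulfonyl sulfur could separate, and whether a short chain such as ethyl would already produce part of it. Also open, on these data alone, is whether the fluoro elsewhere would have the same effect with methyl on the sulfonyl sulfur.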